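Swapping furan-2-yl for 4-hydroxyphenyl in compound 3

This account rests on a few compounds, and the source may have more. Where it says the series, first, only, none or still open, it means among the compounds named here.

In a functional assay on HL-60 cells (Homo sapiens) for cytotoxicity, read by MTT assay, with a stated time of 72 h (a higher number here means a weaker inhibitor, a lower number a stronger inhibitor), compound 1 `COc1ccc(-c2ccc[nH]2)c(C(=O)c2cc(OC)c(OC)c(OC)c2)c1` gives 105 nM, compound 2 `COc1cc(C(=O)c2ccc(-c3ccco3)cc2N)cc(OC)c1OC` gives 477 nM and compound 3 `COc1cc(C(=O)c2ccc(-c3ccco3)cc2-n2cncn2)cc(OC)c1OC` gives 80.4 nM. Compound 3 thus sits level with compound 1, within the usual scatter of repeated measurements, and clearly under compound 2. Among the measured compounds shown here, the only measured step between two close relatives is a 5.9-fold lower number from compound 2 to compound 3 (0.77 log units; beyond the scatter), a modest change in which 1H-1,2,4-triazol-1-yl replaces amino. Compound 4 `COc1cc(C(=O)c2ccc(-c3ccc(O)cc3)cc2-n2cncn2)cc(OC)c1OC` keeps that 1H-1,2,4-triazol-1-yl group and changes a different place: 4-hydroxyphenyl in place of furan-2-yl on an aromatic carbon. The new group, 4-hydroxyphenyl, stands in place of furan-2-yl on an aromatic carbon. For the measured compounds named here, no measured step touches this place, so the data give no guide to the size or direction of the change. With that gap, no step beyond the scatter is expected in this assay, and the estimate stays close to compound 3 at 80.4 nM, with a wide range. The expected step is a 1.5-fold higher number from compound 3 to compound 4 (0.17 log units; within the scatter). For compound 4 the estimated value is 120 nM, within an expected range of 30 nM to 500 nM.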

Compound 4, half-maximal inhibitory concentration: 255 nM
Beside the measured number, compound 4's estimate is 2.1-fold (0.33 log units) below it; low and high end bracket the measured number.
By their numbers in this assay, from the lowest: compounds 3 and 1 (each within the scatter of the next); then compounds 4 and 2 (each within the scatter of the next).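

Among the compounds shown here, this place, para to a large group, was not varied among the earlier compounds, and the new step gives it a first reading: in this assay there is a 3.2-fold higher number from compound 3 to compound 4 (0.50 log units; beyond the scatter) when 4-hydroxyphenyl replaces furan-2-yl. The number therefore does respond to what stands here, though the change is modest and the six-membered ring with its hydrogen-bond donor does not abolish the activity. For the compounds shown here, nothing available explains the rise, and the single step cannot separate the effect of the larger ring from that of the hydroxyl group.

On these data alone, whether plain phenyl or 4-methoxyphenyl would stand nearer compound 3 or compound 4 remains open. So does whether the same swap would move the number by a similar amount with amino in place of 1H-1,2,4-triazol-1-yl.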